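Swapping dimethylamino for diethylamino on a sulfonyl sulfur

The source may hold more compounds than are shown below. What is called first, only, known or untested is meant among the compounds shown, and "the series" means these compounds.

Of the compounds shown here, three sharing one core have been tested in a functional assay on MIA PaCa-2 cells (Homo sapiens) for inhibition, read by MTT assay, with a stated time of 3 days; a higher number here means a weaker inhibitor, a lower number a stronger inhibitor. Compound 1, `CCN(CC)S(=O)(=O)c1ccc(S(=O)(=O)N2CCC[C@@H](C(=O)N[C@H]3CC[C@H](OC)CC3)C2)cc1`, carries a (4-methoxycyclohexyl)amino group on its carbonyl carbon. In this assay compound 1 gives only a limit, > 10000 nM. Compound 2, `CCN(CC)S(=O)(=O)c1ccc(S(=O)(=O)N2CCC[C@@H](C(=O)N3CCC(OC)CC3)C2)cc1`, has 4-methoxypiperidin-1-yl in place of (4-methoxycyclohexyl)amino on that carbonyl carbon. In this assay compound 2 likewise gives only a limit, > 10000 nM. The step that the two limits leave unreadable from compound 1 to compound 2 is therefore not readable. Compound 3, `CN(C)S(=O)(=O)c1ccc(S(=O)(=O)N2CCC[C@@H](C(=O)N3CCC(F)(F)CC3)C2)cc1`, carries dimethylamino on its sulfonyl sulfur. In this assay compound 3 gives only a limit, > 3000 nM. Compound 3 thus stands at the limit of > 3000 nM in this assay, at which 1 of the 3 values shown sits. The other two values sit at the limit of > 10000 nM in this assay, at which 2 of the 3 values shown sit.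

Compound 4, `CCN(CC)S(=O)(=O)c1ccc(S(=O)(=O)N2CCC[C@@H](C(=O)N3CCC(F)(F)CC3)C2)cc1`, has not been measured. The change is diethylamino in place of dimethylamino on a sulfonyl sulfur. Among the measured compounds shown here, no measured step touches the sulfonyl sulfur, and the single measured step elsewhere has no readable size, so no step beyond the usual scatter is expected. Compound 4 is expected to give about 10000 nM, between 3000 nM and 30000 nM, most likely again as a limit. That estimate means an expected step that the limit leaves unreadable from compound 3 to compound 4.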

Compound 4, half-maximal inhibitory concentration: > 10000 nM
Compound 4: a limit, no number; the forecaster's own chance of this, stated with the estimate: 85%; the middle value lies on the limit itself.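

Compound 4 gives only a limit, as do compound 1, compound 2 and compound 3, so its steps from those three compounds cannot be read. As far as these compounds go, whether a change on the sulfonyl sulfur or the carbonyl carbon affects inhibition in this assay remains open.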